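This account rests on a few compounds, and the source may have more. Where it says the series, first, only, none or still open, it means among the compounds named here.

Compound 1 `O=C(O)[C@@H]1CCCN1C(=O)/C=C/c1ccncc1-c1ccc2ccccc2c1` was examined in an assay on a protein complex for inhibition of CDK8/Cyclin C (Homo sapiens), with a stated time of 1 h, tested at 10 uM (a lower number here means less inhibition, a higher number more inhibition at the concentration tested (going by the name of the read-out)), where compound 1 gives 67%. Of the two compounds measured in this assay, compound 1 stands at the lower number; compound 2 `Cn1ncc2cc(-c3cnccc3/C=C/C(=O)O)ccc21`, the only other one, gives 102%, a number higher by a margin beyond the usual scatter of repeated measurements. Compound 3 `O=C(/C=C/c1ccncc1-c1ccc2ccccc2c1)NC1CC1` has not yet been measured in this assay. It differs from compound 1 in a single place: cyclopropylamino in place of 2-carboxypyrrolidin-1-yl on a carbonyl carbon. Among the compounds with values here, no pair of measured compounds differs at this same place, so nothing measured shows how such a change acts here. The expected size of a number 9 percentage points lower from compound 1 to compound 3 (within the scatter) is therefore small, lying within the usual scatter or a little downward. Compound 3 is expected to give about 58% in this assay, with an estimated range from 28% to 88%.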

Compound 3, a percentage reported as inhibition, at one concentration (the size of the read-out at that concentration, not a potency): 102%
The estimate for compound 3 lay 44 percentage points below the measured number; measured number above the stated range.
By their numbers in this assay, from the lowest: compound 1; then compounds 2 and 3 (each within the scatter of the next).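

In this assay, cyclopropylamino in place of 2-carboxypyrrolidin-1-yl on a carbonyl carbon gives a number 35 percentage points higher from compound 1 to compound 3 (beyond the scatter), the first step read at this place. It shows that the read-out responds to the group held on this carbonyl carbon, and that on the core of compound 1 the entering group, with 4 heavy atoms against 8, loses nothing in inhibition. No measurement at hand speaks to the reason for this step.

The single exchange alters the ring, the stereocentre and the carboxylic acid together, so the compounds shown do not separate their shares in the step. An unsubstituted pyrrolidin-1-yl, or an open-chain ethylamino group, on the same carbonyl carbon would bear on that question.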